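The source may hold more compounds than are shown below. What is called first, only, known or untested is meant among the compounds shown, and "the series" means these compounds.

Measured so far in an assay on HeLa cells for displacement of a labelled ligand from 5-hydroxytryptamine receptor 6 (Homo sapiens); a higher number here means a weaker inhibitor, a lower number a stronger inhibitor:
compound 1 `O=S(=O)(c1cccc(Cl)c1)c1cccc2oc(N3CCNCC3)nc12` gives 31 nM
compound 2 `O=S(=O)(c1ccc(C(F)(F)F)cc1)c1cccc2oc(N3CCNCC3)nc12` gives 33 nM
compound 3 `O=S(=O)(c1cccc2ccccc12)c1cccc2oc(N3CCNCC3)nc12` gives 3.1 nM

Compound 3 holds the lowest number of the three in this assay. Its nearest neighbour is compound 1, and that gap is already beyond the scatter; the gap to compound 2 is slightly larger and also beyond the scatter. Among the measured compounds shown here, all three measured compounds carry the same unsubstituted piperazin-1-yl on the shared core, so they differ only in the ring attached to the sulfonyl, and no pair among them isolates a change on the ring nitrogen.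

Compound 4 `CCCN1CCN(c2nc3c(S(=O)(=O)c4cccc5ccccc45)cccc3o2)CC1` has not yet been measured in this assay. It differs from compound 3 by propyl in place of hydrogen on an amine nitrogen in a ring. Nothing measured here speaks to this kind of change, so the expectation rests on compound 3 alone, which gives 3.1 nM. A modest rise in the number is expected, a 2.6-fold higher number from compound 3 to compound 4 (0.41 log units; beyond the scatter), of a size that may or may not exceed the scatter. For compound 4 the estimate is 8 nM, with a range from 2 nM to 30 nM.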

Compound 4, inhibition constant: 36 nM
Beside the measured number, compound 4's estimate is 4.5-fold (0.65 log units) below it, outside the stated range (above it).
By their numbers in this assay, from the lowest: compound 3; then compounds 1, 2 and 4 (each within the scatter of the next).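

In this assay, replacing hydrogen with propyl on the amine nitrogen in a ring, the change from piperazin-1-yl to 4-propylpiperazin-1-yl, gives a 12-fold higher number from compound 3 to compound 4 (1.06 log units; beyond the scatter), a large step beyond the scatter. This is the first reading at this position, since compounds 1, 2 and 3 all carry the same unsubstituted piperazin-1-yl and differ only in the ring on the sulfonyl; the ring nitrogen is now shown to be sensitive to substitution, and with this sulfonyl ring propyl is clearly not tolerated without loss. Nothing measured on these compounds accounts for the size of this step, so it stands as an observation only.

The compounds shown leave open whether the rise scales with chain size, which a methyl or ethyl group on the same nitrogen would test, and whether a chain ending in a hydroxyl group or an amine behaves like propyl. Among the compounds shown here, they also leave open whether propyl produces a step of similar size with the sulfonyl rings of compound 1 and compound 2, as the single step here rests on the ring of compound 3 alone.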